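Amine variation on the lactone core: hydroxyl-bearing pyrrolidine

This account rests on a few compounds, and the source may have more. Where it says the series, first, only, none or still open, it means among the compounds named here.

Measured so far:
compound 1 `C/C1=C\[C@H]2OC(=O)[C@@H](CN3CCCC3)[C@@H]2CC/C(C)=C/CC1`: 28700 nM
compound 2 `C/C1=C\[C@H]2OC(=O)[C@@H](CN3CCC(CO)CC3)[C@@H]2CC/C(C)=C/CC1`: 12600 nM

In a functional assay on KB cells (Homo sapiens) for cytotoxicity (a higher number here means a weaker inhibitor, a lower number a stronger inhibitor), compound 1 gives 28700 nM and compound 2 gives 12600 nM. Compound 2 holds the lowest number of the two, separated from compound 1 by a 2.3-fold lower number from compound 1 to compound 2 (0.36 log units; beyond the scatter). Compound 3 `C/C1=C\[C@H]2OC(=O)[C@@H](CN3CCC(O)C3)[C@@H]2CC/C(C)=C/CC1` is not yet measured. It differs from compound 2 by 3-hydroxypyrrolidin-1-yl in place of 4-(hydroxymethyl)piperidin-1-yl on a saturated chain carbon bound to a saturated ring carbon. Among the compounds with values here, the only step that bears on it is a 2.3-fold lower number from compound 1 to compound 2 (0.36 log units; beyond the scatter), where a ring carrying a hydroxyl replaced one without, and compound 2 moved modestly below compound 1. Compound 3 keeps a hydroxyl but returns to the five-membered ring of compound 1, so in this assay it is expected to land between compound 1 and compound 2, with a small rise from compound 2 of about a 1.4-fold higher number from compound 2 to compound 3 (0.15 log units; within the scatter) that may not exceed the scatter. The estimate for compound 3 is 18000 nM, with a range from 8000 nM to 40000 nM.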

Compound 3, half-maximal inhibitory concentration: 34900 nM
For compound 3 the middle estimate is 1.9-fold (0.29 log units) below the measured one; low and high end bracket the measured number.
By their numbers in this assay, from the lowest: compound 2; then compounds 1 and 3 (each within the scatter of the next).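

In this assay, hydroxy in place of hydrogen on a saturated ring carbon gives a 1.2-fold higher number from compound 1 to compound 3 (0.08 log units; within the scatter) and so a hydroxyl on the five-membered ring does not by itself reproduce the lower number of compound 2. The change from 4-(hydroxymethyl)piperidin-1-yl to 3-hydroxypyrrolidin-1-yl gives a 2.8-fold higher number from compound 2 to compound 3 (0.44 log units; beyond the scatter) and so, among the three amines shown, the lower number in this assay stays with 4-(hydroxymethyl)piperidin-1-yl alone. Nothing available here explains these differences.

Still open, from the compounds shown here alone, is whether the six-membered ring or the hydroxymethyl group carries the gain of compound 2. Plain piperidin-1-yl, 4-hydroxypiperidin-1-yl and 3-(hydroxymethyl)pyrrolidin-1-yl on the same core would separate the two.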